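Benzylamino in place of 4-methylpiperidin-1-yl on the shared core

A few compounds are considered here, and "the series" means these few. Any claim that something is new, unique, unknown or untested is made for them only; others in the source may bear on it.

Two compounds are measured in a functional assay on HCT-116 cells (Homo sapiens) for antiproliferative activity, read by CCK-8 assay, with a stated time of 72 h, tested at 2 uM; a lower number here means a weaker effect, a higher number a stronger effect of the compound at the concentration tested. Compound 1 `CCC(C)n1cnc2c(NCc3ccc(C(=O)Nc4ccccc4N)cc3)nc(Cl)nc21` gives 74.6%. Compound 2 `CC1CCN(c2nc(Cl)nc3c2ncn3Cc2ccc(/C=C/C(=O)Nc3ccccc3N)cc2)CC1` gives 4.24%, the lowest of the two numbers, below compound 1 by a gap beyond the usual scatter. Compound 3 `Nc1ccccc1NC(=O)/C=C/c1ccc(Cn2cnc3c(NCc4ccccc4)nc(Cl)nc32)cc1` is not yet measured; it differs from compound 2 in one place: benzylamino in place of 4-methylpiperidin-1-yl on an aromatic carbon. Among the compounds with values here, no step between measured compounds is known, so the expected size rests on this pair alone. A large upward step in this assay is expected because compound 1, which also carries a benzylamino at that place, gives 74.6%. For compound 3 an inhibition of 50% is expected, with a range of 20% to 80%. That estimate means an expected step of a number 45.8 percentage points higher from compound 2 to compound 3 (beyond the scatter).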

Compound 3, a percentage reported as inhibition, at one concentration (the size of the read-out at that concentration, not a potency): 2.85%
Compound 3: the middle estimate sits 47.2 percentage points above what was measured; measured number below the stated range.
By their numbers in this assay, from the lowest: compounds 3 and 2 (each within the scatter of the next); then compound 1.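

In this assay, benzylamino in place of 4-methylpiperidin-1-yl on this aromatic carbon gives a number 1.4 percentage points lower from compound 2 to compound 3 (within the scatter), so the two groups cannot be told apart at this place with the rest of compound 2 unchanged. Carrying benzylamino here is therefore not enough for a strong read-out, and compound 1 differs from compound 3 in more than one place. No measurement at hand accounts for this result.

Open, on these data alone, is whether a dimethylamino group or a morpholine ring at this place would separate from these two. Also open, as far as these compounds go, is which of the differences between compound 1 and compound 3 goes with the read-out of compound 1.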